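Adding a Second Chloro to an Arginase-1 Inhibitor

The source may report more compounds than this note shows. Statements on the series, on what has been measured and on what is new or still open speak of the compounds shown alone.

Measured compounds:
Compound 1 `CC(C)CCN1CCC(C(N)(CCCCB(O)O)C(=O)O)CC1` gives 180 nM in an assay on isolated protein for inhibition of arginase-1 (Homo sapiens), read by colorimetric assay, with a stated time of 1 h; a higher number here means a weaker inhibitor, a lower number a stronger inhibitor.
Compound 2 `NC(CCCCB(O)O)(C(=O)O)C1CCN(Cc2ccc(Cl)cc2)CC1` gives 190 nM in this assay.

Compound 2 and compound 1 sit within the scatter of each other, so neither can be called the stronger inhibitor on these two numbers. Compound 3 `NC(CCCCB(O)O)(C(=O)O)C1CCN(Cc2ccc(Cl)c(Cl)c2)CC1` differs from compound 2 by one change: chloro in place of hydrogen on an aromatic carbon, on an aromatic carbon of a six-membered aromatic ring of carbon only, ortho to a chloro group and meta to a large group. Among the compounds with values here, the only measured step that touches this end of the molecule is a 1.1-fold higher number from compound 1 to compound 2 (0.02 log units; within the scatter), where a whole 4-chlorophenyl replaced an isobutyl with no shift beyond the scatter. A single extra chloro on that ring is a smaller change, so the expected step is a 1.1-fold higher number from compound 2 to compound 3 (0.02 log units; within the scatter), meaning none beyond the scatter. Compound 3 is therefore estimated at 200 nM, with a range from 100 nM to 400 nM.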

Compound 3, half-maximal inhibitory concentration in the arginase-1 assay: 200 nM
For compound 3 middle estimate and measured number coincide at the digits printed, and the stated range covers the measured number.
By their numbers in the arginase-1 assay, from the lowest: compounds 1, 2 and 3 (each within the scatter of the next).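

Within the data shown here, this is the first change made directly on the aromatic ring, and in the arginase-1 assay the added chloro gives a 1.1-fold higher number from compound 2 to compound 3 (0.02 log units; within the scatter). Measured against the isobutyl end of the series, the 3,4-dichlorophenyl group gives a 1.1-fold higher number from compound 1 to compound 3 (0.05 log units; within the scatter), so in these three compounds neither the smaller nor the larger change moves the inhibition number beyond the scatter. In a physicochemical assay for lipophilicity, using the shake flask method, in phosphate buffer, measured as octanol-water partition (on this read-out lower numbers stand for lower lipophilicity and higher numbers for higher lipophilicity), compound 2 gives 0.3 and compound 3 gives 1.5. The chloro does register in the physicochemical assay, which shows that at this position lipophilicity can rise while the arginase-1 number stays within the scatter: the measured distribution coefficient of compound 2, 0.3, and of compound 3, 1.5, a number 1.20 log units higher (beyond the scatter)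

Going by these compounds, whether this holds only for chloro stays open, since a group of another kind at the same place, such as an amine, a carboxylic acid or a nitrile, could behave differently. Such groups would show how much variety this position accepts.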